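From 2-Fluorophenyl to 3,4-Difluorophenyl: an Untested Analogue

The source may report more compounds than this note shows. Statements on the series, on what has been measured and on what is new or still open speak of the compounds shown alone.

Of the compounds shown here, two built on a shared core have been measured in a functional assay on BCG823 cells (Homo sapiens) for inhibition, read by MTT assay, with a stated time of 72 h; a higher number here means a weaker inhibitor, a lower number a stronger inhibitor. Compound 1 `CN(C(=O)NC(=O)c1ccc(Cl)cc1Cl)c1nc(C(F)(F)F)c(C(=O)N/N=C/c2ccc(C(F)(F)F)cc2)s1` gives 3.08 ug/mL in this assay. Compound 2 `CN(C(=O)NC(=O)c1ccccc1F)c1nc(C(F)(F)F)c(C(=O)N/N=C/c2cc(C(F)(F)F)cc(C(F)(F)F)c2)s1` gives 4.23 ug/mL, the higher of the two numbers, yet it lies within the scatter of compound 1, so the two cannot be told apart. Compound 3 `CN(C(=O)NC(=O)c1ccc(F)c(F)c1)c1nc(C(F)(F)F)c(C(=O)N/N=C/c2cc(C(F)(F)F)cc(C(F)(F)F)c2)s1` has not yet been measured. It differs from compound 2 in one place: 3,4-difluorophenyl in place of 2-fluorophenyl on a carbonyl carbon. Among the measured compounds shown here, no pair of measured compounds shows what this exchange does. For the measured compounds named here, with only two measured compounds, both close together, there is no ground for expecting a move in either direction beyond the scatter. The expected step is accordingly small, a 1.1-fold lower number from compound 2 to compound 3 (0.02 log units; within the scatter). Compound 3 is estimated at 4 ug/mL in this assay, with a range from 2 ug/mL to 8 ug/mL.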

Compound 3, half-maximal inhibitory concentration: 3.51 ug/mL
Compound 3: the middle estimate sits 1.1-fold (0.06 log units) above what was measured; measured number inside the range.
By their numbers in this assay, from the lowest: compounds 1, 3 and 2 (each within the scatter of the next).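

In this assay, 3,4-difluorophenyl in place of 2-fluorophenyl on a carbonyl carbon gives a 1.2-fold lower number from compound 2 to compound 3 (0.08 log units; within the scatter). Among the compounds shown here, this is the first measured pair that isolates a change at this position, and it shows that this exchange, with its one extra fluorine and its different fluorine pattern on the ring, leaves compound 2 and compound 3 indistinguishable. Nothing measured here offers an explanation for this outcome.

Going by these compounds, whether a different kind of group on this carbonyl carbon, such as a pyridine ring, a methoxyphenyl or a simple alkyl chain, would shift the number beyond the scatter remains open. On these data alone, it is also open whether this same exchange would again make no discernible difference if the rest of compound 2 were changed.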